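The source may report more compounds than this note shows. Statements on the series, on what has been measured and on what is new or still open speak of the compounds shown alone.

Measured in a functional assay on KYSE-450 cells (Homo sapiens) for inhibition, read by MTT assay, with a stated time of 48 h; a lower number here means a stronger inhibitor, a higher number a weaker inhibitor:
- compound 1 `COc1ccc(CN(C(C)=O)c2cc(OC)c(OC)c(OC)c2)cc1O`: 160 nM
- compound 2 `CCC/C=C/C(=O)N(Cc1ccc(OC)c(O)c1)c1cc(OC)c(OC)c(OC)c1`: 57 nM
- compound 3 `COc1ccc(CN(C(=O)CCCl)c2cc(OC)c(OC)c(OC)c2)cc1O`: 110 nM

Compound 3 holds the middle number of the three, but it cannot be separated from either neighbour, with a 1.5-fold lower number from compound 1 to compound 3 (0.16 log units; within the scatter) and a 1.9-fold higher number from compound 2 to compound 3 (0.29 log units; within the scatter). Only a 2.8-fold lower number from compound 1 to compound 2 (0.45 log units; beyond the scatter) exceeds the scatter.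

Compound 4 `C/C=C/C(=O)N(Cc1ccc(OC)c(O)c1)c1cc(OC)c(OC)c(OC)c1` carries prop-1-en-1-yl in place of 2-chloroethyl on a carbonyl carbon. The nearest measured counterpart is the pent-1-en-1-yl of compound 2, so a 1.9-fold higher number from compound 2 to compound 3 (0.29 log units; within the scatter) bears most directly, read in reverse. A small shift toward compound 2 is therefore expected in this assay, but nothing beyond the scatter.

For compound 4 the estimated step is a 1.4-fold lower number from compound 3 to compound 4 (0.14 log units; within the scatter). Compound 4 is expected at 80 nM, with an estimated range of 38 nM to 170 nM.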

Compound 4, half-maximal inhibitory concentration: 67 nM
The estimate for compound 4 lay 1.2-fold (0.08 log units) above the measured number; measured number inside the range.
By their numbers in this assay, from the lowest: compounds 2, 4, 3 and 1 (each within the scatter of the next, the first and the last beyond it).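

On the carbonyl carbon whose other neighbour is the amide-type nitrogen, prop-1-en-1-yl cannot be separated from pent-1-en-1-yl (a 1.2-fold higher number from compound 2 to compound 4 (0.07 log units; within the scatter)) or from 2-chloroethyl (a 1.6-fold lower number from compound 3 to compound 4 (0.22 log units; within the scatter)). Against methyl, however, it stands apart (a 2.4-fold lower number from compound 1 to compound 4 (0.38 log units; beyond the scatter)), so a second alkenyl group now clears the scatter from compound 1, which 2-chloroethyl does not. No measurement shown explains these steps.

From the compounds shown here alone, whether a saturated propyl chain would match prop-1-en-1-yl remains open. So does the effect of a terminal amine or carboxylic acid on this chain.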